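Adding a Second Hydroxy to Compound 3

A few compounds are considered here, and "the series" means these few. Any claim that something is new, unique, unknown or untested is made for them only; others in the source may bear on it.

In a functional assay on HeLa cells (Homo sapiens) for inhibition, read by MTT assay, with a stated time of 48 h (a higher number here means a weaker inhibitor, a lower number a stronger inhibitor), compound 1 `COc1ccc(-c2nnnn2-c2cc(OC)c(OC)c(OC)c2)c(O)c1O` gives 950 nM and compound 2 `COc1ccc(-c2nnnn2-c2cc(OC)c(OC)c(OC)c2O)cc1` gives 92000 nM. Compound 3 `COc1ccc(-c2nnnn2-c2cc(OC)c(OC)c(OC)c2)c(O)c1` gives 2400 nM, the middle of the three numbers. Compound 4 `COc1ccc(-c2nnnn2-c2cc(OC)c(OC)c(OC)c2O)c(O)c1` has hydroxy in place of hydrogen on an aromatic carbon of compound 3 (hydroxy in place of hydrogen on an aromatic carbon). Going by the values given here, the only measured step, a 2.5-fold higher number from compound 1 to compound 3 (0.40 log units; beyond the scatter), is modest, but it concerns a hydroxy on another aromatic carbon, so it offers limited guidance. Lacking the hydroxy of compound 3 and carrying the entering hydroxy, compound 2 gives 92000 nM, so a higher number is expected. The expected change is a 5.0-fold higher number from compound 3 to compound 4 (0.70 log units; beyond the scatter). The estimate for compound 4 is 12000 nM, with an expected range of 2500 nM to 60000 nM.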

Compound 4, half-maximal inhibitory concentration: 45000 nM
Beside the measured number, compound 4's estimate is 3.8-fold (0.57 log units) below it; the measured number falls inside the stated range.
By their numbers in this assay, from the lowest: compound 1; then compound 3; then compound 4; then compound 2.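

In this assay, going by these compounds alone, hydroxy in place of hydrogen on this aromatic carbon, ortho to a large group and to a methoxy group, proves a large loss (a 19-fold higher number from compound 3 to compound 4 (1.27 log units; beyond the scatter)), which the earlier compounds did not reveal. Hydroxy in place of hydrogen at the other site still lowers the number (a 2.0-fold lower number from compound 2 to compound 4 (0.31 log units; beyond the scatter)) with this hydroxy present, so that step holds with or without it: the same change on two cores in this assay, a 2.5-fold higher number (0.40 log units; beyond the scatter) from compound 1 to compound 3 and a 2.0-fold higher number (0.31 log units; beyond the scatter) from compound 4 to compound 2, 1.2-fold (0.09 log units) apart, within the scatter of two such steps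

On these data alone, how an amine, a fluorine or an ethoxy group would read on this carbon stays open. The compounds shown also cannot tell what lies behind the loss.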